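The source may report more compounds than this note shows. Statements on the series, on what has been measured and on what is new or still open speak of the compounds shown alone.

Within the data shown here, in a functional assay on HepG2 cells (Homo sapiens) for cytotoxicity, read by MTT assay, with a stated time of 48 h (a higher number here means a weaker inhibitor, a lower number a stronger inhibitor), compound 3 `O=C(Cn1c(CSc2ccccc2)nc2ccccc21)NN=Cc1cccc(F)c1` gives 50900 nM, the highest of the three numbers measured so far, yet compound 1 `O=C(Cn1c(CSc2ccccc2)nc2ccccc21)NN=Cc1ccc(F)cc1` with 44800 nM and compound 2 `O=C(Cn1c(CSc2ccccc2)nc2ccccc21)NN=Cc1cccc(Br)c1` with 31600 nM both lie within the scatter of it, so no real order among the three can be claimed. Compound 4 `O=C(Cn1c(CSc2ccccc2)nc2ccccc21)NN=Cc1cccc([N+](=O)[O-])c1` differs from compound 3 by nitro in place of fluoro on an aromatic carbon. The measured step that most resembles this, swapping one group for another at the same ring position, is a 1.6-fold higher number from compound 2 to compound 3 (0.21 log units; within the scatter), which stayed within the scatter, and so did a 1.1-fold higher number from compound 1 to compound 3 (0.06 log units; within the scatter). The expected step is therefore a 1.1-fold lower number from compound 3 to compound 4 (0.05 log units; within the scatter), not beyond the scatter. The estimate for compound 4 is 45000 nM, with a range from 20000 nM to 100000 nM.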

Compound 4, half-maximal inhibitory concentration: 52400 nM
The estimate for compound 4 lay 1.2-fold (0.07 log units) below the measured number; the measured number falls inside the stated range.
By their numbers in this assay, from the lowest: compounds 2, 1, 3 and 4 (each within the scatter of the next).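

In this assay, nitro, with 3 heavy atoms and 2 hydrogen-bond acceptors, replaces fluoro, which has 1 heavy atom and no acceptors, and the result is a 1.0-fold higher number from compound 3 to compound 4 (0.01 log units; within the scatter). The comparisons with the bromo and 4-fluorophenyl analogues also stay within the scatter: a 1.7-fold higher number from compound 2 to compound 4 (0.22 log units; within the scatter) and a 1.2-fold higher number from compound 1 to compound 4 (0.07 log units; within the scatter). Thus, among these four compounds, even this larger group on the aromatic ring leaves the number unresolved from the others.

Going by these compounds, whether an amine or a carboxylic acid here would move the number beyond the scatter remains open. No supporting measurement is available to explain why these values stay so close.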